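Thiazolyl for pyrimidinyl on the sulfonamide nitrogen

A few compounds are considered here, and "the series" means these few. Any claim that something is new, unique, unknown or untested is made for them only; others in the source may bear on it.

Compound 3 `C=C1CC[C@@H]2[C@](C)(COC(C)=O)[C@H](OC(C)=O)CC[C@@]2(C)[C@H]1CC(Nc1ccc(S(=O)(=O)Nc2ncccn2)cc1)C1=CCOC1=O` was tested in a functional assay on PC-3 cells (Homo sapiens) for inhibition, read by sulforhodamine B assay, with a stated time of 48 h (on this read-out lower numbers stand for stronger inhibition of growth and higher numbers for weaker inhibition of growth), where compound 3 gives 5070 nM, the second highest of the three numbers. Compound 1 `C=C1CC[C@@H]2[C@](C)(COC(C)=O)[C@H](OC(C)=O)CC[C@@]2(C)[C@H]1CC(Nc1ccc(S(=O)(=O)Nc2cc(C)on2)cc1)C1=CCOC1=O` gives 4310 nM, and compound 2 `C=C1CC[C@@H]2[C@](C)(COC(C)=O)[C@H](OC(C)=O)CC[C@@]2(C)[C@H]1CC(Nc1ccc(S(=O)(=O)Nc2nccc(C)n2)cc1)C1=CCOC1=O` gives 15700 nM; there is a 1.2-fold higher number from compound 1 to compound 3 (0.07 log units; within the scatter), whereas there is a 3.1-fold lower number from compound 2 to compound 3 (0.49 log units; beyond the scatter). Compound 4 `C=C1CC[C@@H]2[C@](C)(COC(C)=O)[C@H](OC(C)=O)CC[C@@]2(C)[C@H]1CC(Nc1ccc(S(=O)(=O)Nc2nccs2)cc1)C1=CCOC1=O` differs from compound 3 by 1,3-thiazol-2-yl in place of pyrimidin-2-yl on a sulfonamide nitrogen. The measured exchanges of the heteroaryl group on this nitrogen, a 1.2-fold higher number from compound 1 to compound 3 (0.07 log units; within the scatter) and a 3.6-fold higher number from compound 1 to compound 2 (0.56 log units; beyond the scatter), ranged from within the scatter to modest, so no step beyond the scatter is expected in this assay, the expected step being a 1.0-fold lower number from compound 3 to compound 4 (0.01 log units; within the scatter). Compound 4 is therefore estimated at 5000 nM, within 2000 nM to 13000 nM.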

Compound 4, concentration for total growth inhibition: 21500 nM
For compound 4 the middle estimate is 4.3-fold (0.63 log units) below the measured one; measured number above the stated range.
By their numbers in this assay, from the lowest: compounds 1 and 3 (each within the scatter of the next); then compounds 2 and 4 (each within the scatter of the next).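

In this assay, the heteroaryl group on the sulfonamide nitrogen matters even without a methyl group: a 4.2-fold higher number from compound 3 to compound 4 (0.63 log units; beyond the scatter), and a 5.0-fold higher number from compound 1 to compound 4 (0.70 log units; beyond the scatter), while a 1.4-fold higher number from compound 2 to compound 4 (0.14 log units; within the scatter). Going by these compounds alone, earlier, the only rise among the compounds came with a methyl group on the pyrimidine ring, but the methyl-free thiazolyl group of compound 4 gives a number as high as that of compound 2. No evidence is available to explain this difference. The compounds shown leave open how a pyridin-2-yl ring or an acetyl group on this nitrogen would compare.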